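The compounds below may be only part of what the source reports. "The series", "measured", "known", "first", "only" and "open" are said of these compounds alone.

Compound 1 `N#Cc1c(Oc2ccccc2)sc(C(=O)c2ccc([N+](=O)[O-])cc2)c1N` and compound 2 `Cc1cccc(Oc2sc(C(=O)c3ccc([N+](=O)[O-])cc3)c(N)c2C#N)c1` are built on one core and differ only by methyl in place of hydrogen on an aromatic carbon. In a physicochemical assay for lipophilicity (on this read-out higher numbers stand for higher lipophilicity and lower numbers for lower lipophilicity), compound 1 gives 4.53 and compound 2 gives 5.03, so that change made a number 0.50 log units higher from compound 1 to compound 2 (beyond the scatter). Compound 3 `COC(=O)c1sc(Oc2ccccc2)c(C(N)=O)c1N` sits on another core; the difference between the two cores is not broken down here. In this assay compound 3 gives 3.11, the lowest of the three. Compound 4 `COC(=O)c1sc(Oc2cccc(C)c2)c(C(N)=O)c1N` differs from compound 3 by methyl in place of hydrogen on an aromatic carbon, the same change at the same kind of place as between compound 1 and compound 2. Among the compounds with values here, that single earlier step, a number 0.50 log units higher from compound 1 to compound 2 (beyond the scatter), is the only guide, and the cores differ. A step of roughly that size is nonetheless expected, a number 0.50 log units higher from compound 3 to compound 4 (beyond the scatter). Compound 4 is therefore estimated in this assay at 3.61, most likely between 3.3 and 3.95.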

Compound 4, partition coefficient: 3.61
Compound 4: middle estimate and measured number agree at the digits printed, within the range that was stated.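

In this assay, going from phenyl to 3-methylphenyl gives a number 0.50 log units higher from compound 3 to compound 4 (beyond the scatter), which matches the earlier step of a number 0.50 log units higher from compound 1 to compound 2 (beyond the scatter), so on these two cores the change carried over at the same size. Within the data shown here, with only two pairs on two cores, this does not show that the step would hold on a further core, or for methyl at another place on the ring. Nothing measured here explains why the step has this size.

The compounds shown leave open whether a different group on the same ring, such as an amine, a carboxylic acid or a longer chain, would also give matching steps on both cores. They also leave open how a second methyl would behave.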